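A few compounds are considered here, and "the series" means these few. Any claim that something is new, unique, unknown or untested is made for them only; others in the source may bear on it.

Measured so far in an assay on isolated protein for inhibition of RAC-alpha serine/threonine-protein kinase (Homo sapiens), read by ELISA, tested at 100 uM; a lower number here means less inhibition, a higher number more inhibition at the concentration tested (going by the name of the read-out):
compound 1, `CCCCCCCCO[C@@H]1O[C@H](CS(=O)(=O)O)[C@@H](O)[C@H](O)[C@H]1O`, gives 14%
compound 2, `CCCCCC(=O)OCC(CO)O[C@@H]1O[C@H](CS(=O)(=O)O)[C@@H](O)[C@H](O)[C@H]1O`, gives 18%

Among the compounds with values here, compound 2 and compound 1 sit together inside the usual scatter of this assay; the two numbers do not separate, and no step between measured compounds is available.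

Compound 3 is `CCCCCCCCCCCC(=O)OCC(CO)O[C@@H]1O[C@H](CS(=O)(=O)O)[C@@H](O)[C@H](O)[C@H]1O`. Against compound 2 the difference is hexyl in place of hydrogen on a saturated chain carbon, five bonds along the chain from a carbonyl carbon. Nothing measured here bears on a change of this kind. For compound 3 the step is estimated at a number 4 percentage points higher from compound 2 to compound 3 (within the scatter), none beyond the scatter, with only a slight lean upward. Compound 3 is expected to give 22% in this assay, within a range from 8% to 40%.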

Compound 3, a percentage reported as inhibition, at one concentration (the size of the read-out at that concentration, not a potency): 31%
Beside the measured number, compound 3's estimate is 9 percentage points below it; low and high end bracket the measured number.
By their numbers in this assay, from the lowest: compounds 1 and 2 (each within the scatter of the next); then compound 3.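

Hexyl in place of hydrogen on a saturated chain carbon, five bonds along the chain from a carbonyl carbon, gives the only step in this assay that can be read so far: a number 13 percentage points higher from compound 2 to compound 3 (beyond the scatter). Within the data shown here, compound 1 and compound 2 did not separate, so this is the first sign that the series responds to a change, and that this chain position is one where the read-out moves. Nothing available accounts for the rise.

A single step cannot show whether the number follows chain length in general. From the compounds shown here alone, whether a longer chain, or a chain ending in an amine or a carboxylic acid, would move the read-out further remains open.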